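Swapping an aromatic ring for a saturated one on a ketone

The compounds below may be only part of what the source reports. "The series", "measured", "known", "first", "only" and "open" are said of these compounds alone.

Three compounds share a core in which a benzoic acid is joined through a carbonyl to a second benzene ring, which then carries a further group. Compound 1 `O=C(O)c1ccc(C(=O)c2ccc(C(=O)c3ccc(Cl)cc3)cc2)cc1` ends in a 4-chlorophenyl ketone, and in an assay on CHO cells for inhibition of 3-oxo-5-alpha-steroid 4-dehydrogenase 2 (Homo sapiens) (a lower number here means a stronger inhibitor, a higher number a weaker inhibitor), compound 1 gives 35 nM. Compound 2 `O=C(O)c1ccc(C(=O)c2ccc(C(=O)c3ccc(C(F)(F)F)cc3)cc2)cc1` carries a trifluoromethyl instead of the chlorine, and in this assay compound 2 gives 30 nM; the step of a 1.2-fold lower number from compound 1 to compound 2 (0.07 log units; within the scatter) is within the scatter. Compound 3 `O=C(O)c1ccc(C(=O)c2ccc(-c3ccc(Cl)cc3Cl)cc2)cc1` has the outer ring attached directly, without a carbonyl, and in this assay compound 3 gives 85 nM. On these numbers compound 1 stands second highest of the three, close to compound 2 and furthest from compound 3.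

Compound 4 `O=C(O)c1ccc(C(=O)c2ccc(C(=O)C3CCCCC3)cc2)cc1` is not yet measured. It differs from compound 1 by cyclohexyl in place of 4-chlorophenyl on a carbonyl carbon. Among the measured compounds shown here, no measured step touches this kind of change; the only step known, from compound 1 to compound 2, was within the scatter and concerns a substituent on an aromatic ring that compound 4 no longer has. Without a matching precedent, a modest weakening beyond the scatter is expected, a 2.9-fold higher number from compound 1 to compound 4 (0.46 log units; beyond the scatter), so compound 4 is estimated at 100 nM, with a likely range from 30 nM to 400 nM.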

Compound 4, inhibition constant: 30 nM
For compound 4 the middle estimate is 3.3-fold (0.52 log units) above the measured one; the range from low to high includes it.
By their numbers in this assay, from the lowest: compounds 2, 4 and 1 (each within the scatter of the next); then compound 3.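

With cyclohexyl in place of 4-chlorophenyl on a carbonyl carbon, this assay shows a 1.2-fold lower number from compound 1 to compound 4 (0.07 log units; within the scatter) and so cannot tell the saturated ring from the aromatic one, which means an aromatic ring at this spot is not needed for a value in this range. Compound 4 also compares well with the compound whose outer ring is attached directly, with a 2.8-fold lower number from compound 3 to compound 4 (0.45 log units; beyond the scatter) as the result, although that step changes both the ring and the carbonyl link at once and cannot be credited to either alone. Nothing available explains why the two rings read alike.

Still open, from the compounds shown here alone, is how far this tolerance extends: whether a smaller cyclopentyl ring or an open hexyl chain on the same carbonyl would read the same. A ring carrying an amine, such as piperidine, is also untested among these compounds.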